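Fluoro in Place of Bromo: What Compound 4 Might Give

The source may report more compounds than this note shows. Statements on the series, on what has been measured and on what is new or still open speak of the compounds shown alone.

Measured in a functional assay on thoracic aorta (Rattus norvegicus, strain Wistar), with a stated time of 15 min; on this read-out lower numbers stand for an effect already at smaller amounts and higher numbers for an effect only at larger amounts of compound:
compound 1 `CCOc1ccc(F)cc1C(C)NC(=O)N(C)S(=O)(=O)c1ccc(C)cc1`: 7800 nM
compound 3 `CCOc1ccc(Br)cc1C(C)NC(=O)N(C)S(=O)(=O)c1ccc(C)cc1`: 28600 nM
compound 2 `COc1ccc(Br)cc1C(C)NC(=O)NS(=O)(=O)c1ccc(C)cc1`: > 300000 nM, which is a limit of the assay and not a number.

Compound 2 sits at the limit of > 300000 nM in this assay, at which 1 of the 3 values shown sits. Between compound 3 and compound 1 the change is fluoro in place of bromo on an aromatic carbon, and it gave a 3.7-fold lower number from compound 3 to compound 1 (0.56 log units; beyond the scatter). The difference between the core of compound 2 and the core of compound 3 is not broken down here. Compound 4 `COc1ccc(F)cc1C(C)NC(=O)NS(=O)(=O)c1ccc(C)cc1`, not yet measured, differs from compound 2 by fluoro in place of bromo on an aromatic carbon; this is the same kind of change as that from compound 3 to compound 1, not the same one, since the leaving bromo here sits para to a methoxy group rather than para to an ethoxy group (3 heavy atoms). Because compound 2 gives only > 300000 nM, the step to compound 4 cannot be read from a number. Compound 4 is therefore expected to give 150000 nM in this assay, roughly 40000 nM to 600000 nM, an expected step of an at least 2.0-fold lower number from compound 2 to compound 4 (0.30 log units; that floor lies within the scatter), and it may again come out only as a limit.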

Compound 4, half-maximal effective concentration: > 300000 nM
Compound 4 gave a limit, no number; the forecaster's own chance of this, stated with the estimate: 50%; middle value at least 2.0-fold (0.30 log units) from the limit.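

Compound 2 and compound 4 both sit at a limit of this assay and not at a number, so no step between them can be read: the limit of > 300000 nM in this assay, at which 2 of the 4 values shown sit.

On these data alone, whether fluoro in place of bromo changes the read-out at all on the core of compound 2 remains open.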